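The source may report more compounds than this note shows. Statements on the series, on what has been measured and on what is new or still open speak of the compounds shown alone.

Measured so far:
compound 1 `O=C1c2c[n+]([O-])c3ccccc3c2C(=O)c2c1c1ccccc1n2Cc1cn([C@H]2O[C@H](CO)[C@@H](O)[C@H]2O)nn1` — 1490 nM
compound 2 `O=C1c2c[n+]([O-])c3ccccc3c2C(=O)c2c1c1ccccc1n2Cc1cn([C@@H]2O[C@H](CO)[C@@H](O)[C@H](O)[C@H]2O)nn1` — 590 nM

In a functional assay on MCF7 cells (Homo sapiens) for cytotoxicity, read by MTT assay, with a stated time of 72 h (on this read-out higher numbers stand for weaker inhibition and lower numbers for stronger inhibition), compound 1 gives 1490 nM, the highest of the two numbers; compound 2 gives 590 nM. Going by the values given here, the only measured step is a 2.5-fold lower number from compound 1 to compound 2 (0.40 log units; beyond the scatter), an exchange of one sugar ring for another on the aromatic nitrogen. Among the compounds with values here, compound 3 `O=C1c2c[n+]([O-])c3ccccc3c2C(=O)c2c1c1ccccc1n2Cc1cn(C[C@@H](O)CO)nn1` differs from compound 1 by 2,3-dihydroxypropyl in place of 3,4-dihydroxy-5-(hydroxymethyl)oxolan-2-yl on an aromatic nitrogen, a ring replaced by an open chain, which no measured step covers directly. The sugar change moved the number only modestly, so a step of modest size at most is expected, with no clear direction. Compound 3 is expected to give 1500 nM (600 nM to 4000 nM) in this assay. The expected step is a 1.0-fold higher number from compound 1 to compound 3 (0.00 log units; within the scatter).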

Compound 3, half-maximal inhibitory concentration: 600 nM
The estimate for compound 3 lay 2.5-fold (0.40 log units) above the measured number, and the stated range covers the measured number.
By their numbers in this assay, from the lowest: compounds 2 and 3 (each within the scatter of the next); then compound 1.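

In this assay the open 2,3-dihydroxypropyl chain in place of 3,4-dihydroxy-5-(hydroxymethyl)oxolan-2-yl on the aromatic nitrogen gives a 2.5-fold lower number from compound 1 to compound 3 (0.40 log units; beyond the scatter) and so shows that a sugar ring at this position is not needed to reach the level of compound 2. Against 3,4,5-trihydroxy-6-(hydroxymethyl)oxan-2-yl the chain gives a 1.0-fold higher number from compound 2 to compound 3 (0.01 log units; within the scatter) and the two groups stand level. Nothing available explains these numbers. Open, on these data alone, is how an amine, a carboxylic acid or a longer chain on this aromatic nitrogen would compare with the 2,3-dihydroxypropyl chain of compound 3.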